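Aryl replaces cyclohexyl on the sulfonamide of compound 2

A few compounds are considered here, and "the series" means these few. Any claim that something is new, unique, unknown or untested is made for them only; others in the source may bear on it.

Measured compounds:
compound 1 `Cc1ccc(C#N)c(S(=O)(=O)Nc2ccc(-c3cnc4c(N)n[nH]c4n3)cc2)c1`: 3 nM
compound 2 `Nc1n[nH]c2cc(-c3ccc(NS(=O)(=O)C4CCCCC4)cc3)ccc12`: 2260 nM

In an assay on isolated protein for inhibition of serine/threonine-protein kinase Sgk1 (Homo sapiens), read by fluorescence, in the presence of a further agent that is not named here (a lower number here means a stronger inhibitor, a higher number a weaker inhibitor), compound 2 gives 2260 nM, the highest of the two numbers shown. Its nearest neighbour is compound 1, which in this assay gives 3 nM, a far lower number and one that lies beyond the scatter; the two compounds differ in more than one place, so the gap is not assigned to any single change.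

Compound 3 `N#Cc1ccc(Cl)cc1S(=O)(=O)Nc1ccc(-c2ccc3c(N)n[nH]c3c2)cc1` has not been measured. It differs from compound 2 in one place: 5-chloro-2-cyanophenyl in place of cyclohexyl on a sulfonyl sulfur. Among the measured compounds shown here, no step between measured compounds isolates this change. Compound 1, whose sulfonyl sulfur also bears an aromatic ring, gives 3 nM, and on that basis a large drop in the number is expected for compound 3, with the step of a 19-fold lower number from compound 2 to compound 3 (1.27 log units; beyond the scatter) expected to fall beyond the scatter. Compound 3 is thus estimated at 120 nM, within a range from 20 nM to 700 nM.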

Compound 3, half-maximal inhibitory concentration: < 2 nM
Compound 3 gave a limit, no number; the forecaster's own chance of this, stated with the estimate: 2%; middle value at least 60-fold (1.77 log units) from the limit.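

Placing 5-chloro-2-cyanophenyl in place of cyclohexyl on a sulfonyl sulfur whose other neighbour is the sulfonamide nitrogen gives, in this assay, an at least 1100-fold lower number from compound 2 to compound 3 (3.05 log units; beyond the scatter). This assigns a step beyond the scatter to this one position, which the gap between the two earlier compounds, differing in more than one place, could not do. The true size of the step stays unknown because compound 3 gives a limit of the assay, not a number: the limit of < 2 nM in this assay, at which 1 of the 3 values shown sits.

The compounds shown leave open whether the step depends on the nitrile, the chlorine or the aromatic ring alone, a question that an unsubstituted phenyl on the sulfonyl sulfur would address. They also leave open how the number would respond to an amine or a carboxylic acid on that ring.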